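From Propanoyl to Methylcarbamoyl: One Small Swap

This account rests on a few compounds, and the source may have more. Where it says the series, first, only, none or still open, it means among the compounds named here.

In a functional assay on the whole organism with Mus musculus as the target, in the maximal electroshock model (a lower number here means that less compound is needed, a higher number that more compound is needed for the effect), compound 1 `OC1CCN(c2ccc(-c3cccc4ccccc34)nn2)CC1` gives 38 mg/kg. Going by the values given here, compound 2 `CCC(=O)OC1CCN(c2ccc(-c3ccc(Cl)cc3Cl)nn2)CC1` gives 50 mg/kg, a number within the usual scatter of the one for compound 1, so the two cannot be told apart here.

Compound 3 `CNC(=O)OC1CCN(c2ccc(-c3ccc(Cl)cc3Cl)nn2)CC1` has not yet been measured. It keeps the core of compound 2 but carries methylamino in place of ethyl on a carbonyl carbon. Put another way, propanoyloxy becomes (methylcarbamoyl)oxy.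

Among the compounds with values here, no two measured compounds differ in just one place, so the data offer no direct guide to this swap. The working expectation in this assay is therefore no change beyond the scatter, in either direction. The expected step of a 1.1-fold lower number from compound 2 to compound 3 (0.05 log units; within the scatter) is correspondingly small. For compound 3 the estimate is 45 mg/kg, with an expected range of 18 mg/kg to 110 mg/kg.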

Compound 3, dose for half-maximal effect: 5.5 mg/kg
Beside the measured number, compound 3's estimate is 8.2-fold (0.91 log units) above it; the measured number lies below the stated range.
By their numbers in this assay, from the lowest: compound 3; then compounds 1 and 2 (each within the scatter of the next).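

Replacing ethyl with methylamino on a carbonyl carbon, which turns propanoyloxy into (methylcarbamoyl)oxy, gives a 9.1-fold lower number from compound 2 to compound 3 (0.96 log units; beyond the scatter) in this assay, so far less compound is needed for the effect. This position is therefore sensitive to a small swap: each group holds 2 heavy atoms, yet the entering methylamino carries 1 hydrogen-bond donor and ethyl carries none. Nothing shown here explains why the number falls, so this difference in donors remains an observation and not a cause.

Still open, from the compounds shown here alone, is whether the hydrogen on the new nitrogen matters, a question that dimethylamino on the same carbonyl carbon could answer. Also open, going by these compounds, is how far the chain can grow, for instance to ethylamino or propylamino, before the low number is lost.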